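Replacing 2-chloro-4-fluorophenyl with 2,4-dihydroxyphenyl

The source may hold more compounds than are shown below. What is called first, only, known or untested is meant among the compounds shown, and "the series" means these compounds.

Compound 1 `N#Cc1ccc(/C=N/NC(=O)Nc2ccc(Oc3ccnc4[nH]ccc34)c(F)c2)cc1` gives "not active" (no number reported)
Compound 2 `O=C(N/N=C/c1ccc(F)cc1Cl)Nc1ccc(Oc2ccnc3[nH]ccc23)c(F)c1` gives 7610 nM

For the measured compounds named here, in a functional assay on MCF7 cells (Homo sapiens) for antiproliferative activity, read by MTT assay, with a stated time of 72 h (a higher number here means a weaker inhibitor, a lower number a stronger inhibitor), compound 2 holds the only number, since compound 1 gave none. Going by the values given here, compound 3 `O=C(N/N=C/c1ccc(O)cc1O)Nc1ccc(Oc2ccnc3[nH]ccc23)c(F)c1`, not yet measured, carries 2,4-dihydroxyphenyl in place of 2-chloro-4-fluorophenyl on a carbon with a double bond to nitrogen as its one change from compound 2. Among the compounds with values here, no measured pair shows the effect of such a change, so no step beyond the scatter is expected in either direction, although a result without a number remains possible. The estimate therefore means only a 1.3-fold lower number from compound 2 to compound 3 (0.10 log units; within the scatter) in this assay as the expected step. Compound 3 is estimated at 6000 nM (expected range 1500 nM to 25000 nM).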

Compound 3, half-maximal inhibitory concentration: 48000 nM
Compound 3: the middle estimate sits 8.0-fold (0.90 log units) below what was measured; the measured number lies above the stated range.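

In this assay, for the compounds shown here, the replacement on a carbon with a double bond to nitrogen gives a 6.3-fold higher number from compound 2 to compound 3 (0.80 log units; beyond the scatter) and so provides the first readable step at this position. The position is therefore not indifferent to this change, even though both groups hold the same number of heavy atoms. Nothing measured here accounts for the step.

The compounds shown leave open whether one hydroxyl or both go with the rise. They also leave open how methoxy groups or an amine on the ring would compare.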